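A few compounds are considered here, and "the series" means these few. Any claim that something is new, unique, unknown or untested is made for them only; others in the source may bear on it.

In an ADME assay on the whole organism (plasma) for pharmacokinetics, with Rattus norvegicus as the target, with a stated time of 24 h, at a dose of 10 mg/kg by the oral route (a higher number here means more compound in the circulation at the dose given, a lower number less compound in the circulation), three compounds with a shared core have been measured, differing only in the group on the sulfonyl sulfur: compound 1 `Cc1ccc2c(c1)c(-c1ccc[nH]c1=O)c(C(=O)NS(C)(=O)=O)n2Cc1cc(F)ccc1F` gives 10400 ng.h/mL, compound 2 `CCS(=O)(=O)NC(=O)c1c(-c2ccc[nH]c2=O)c2cc(C)ccc2n1Cc1cc(F)ccc1F` gives 5340 ng.h/mL, and compound 3 `Cc1ccc2c(c1)c(-c1ccc[nH]c1=O)c(C(=O)NS(=O)(=O)C1CC1)n2Cc1cc(F)ccc1F` gives 4530 ng.h/mL. That is a low place among the three: the data show a 2.3-fold lower number from compound 1 to compound 3 (0.36 log units; beyond the scatter), and a 1.2-fold lower number from compound 2 to compound 3 (0.07 log units; within the scatter). Compound 4 `O=C(NS(=O)(=O)C1CC1)c1c(-c2ccc[nH]c2=O)c2cc(CC(F)(F)F)ccc2n1Cc1cc(F)ccc1F` differs from compound 3 by trifluoromethyl in place of hydrogen on a saturated chain carbon bound to an aromatic carbon, with trifluoromethyl in place of hydrogen on a saturated chain carbon bound to an aromatic carbon. For the measured compounds named here, no measured step touches that place. The closest guide is a small addition elsewhere, a 1.9-fold lower number from compound 1 to compound 2 (0.29 log units; within the scatter). No change beyond the scatter is therefore expected, and the estimated step is a 1.0-fold lower number from compound 3 to compound 4 (0.00 log units; within the scatter). The expected value for compound 4 is 4500 ng.h/mL, within a range of 1700 ng.h/mL to 12000 ng.h/mL.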

Compound 4, area under the concentration-time curve: 379 ng.h/mL
Estimate against measurement, compound 4: 12-fold (1.07 log units) above; the whole stated range lies above it.
By their numbers in this assay, from the lowest: compound 4; then compounds 3, 2 and 1 (each within the scatter of the next, the first and the last beyond it).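

Until now only the group on the sulfonyl sulfur had varied, and those steps were all smaller than this one. In this assay, changing methyl to 2,2,2-trifluoroethyl on the shared core gives a 12-fold lower number from compound 3 to compound 4 (1.08 log units; beyond the scatter), so this place affects the number more than any sulfonyl change shown. Nothing measured here accounts for the drop. As far as these compounds go, whether it comes from the fluorines or from the longer chain alone stays open, and a plain ethyl or a methoxyethyl at this place would help separate the two. Also open, from the compounds shown here alone, is whether the drop holds with methyl or ethyl on the sulfonyl sulfur.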